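A few compounds are considered here, and "the series" means these few. Any claim that something is new, unique, unknown or untested is made for them only; others in the source may bear on it.

In a functional assay on HCT-116 cells (Homo sapiens) for antiproliferative activity, read by MTT assay, with a stated time of 48 h (on this read-out lower numbers stand for stronger inhibition and higher numbers for weaker inhibition), three compounds built on one shared core have been measured. Compound 1 `COc1ccc(N(C)c2ccnc(Cl)n2)cc1` gives 1460 nM, compound 2 `COc1ccc(N(C)c2ccnc(Cl)n2)cc1F` gives 914 nM, and compound 3 `COc1ccc(N(C)c2ccnc(Cl)n2)cc1O` gives 422 nM, the lowest of the three numbers. Fluoro in place of hydrogen on an aromatic carbon gave a 1.6-fold lower number from compound 1 to compound 2 (0.20 log units; within the scatter). Hydroxy in place of hydrogen gave a 3.5-fold lower number from compound 1 to compound 3 (0.54 log units; beyond the scatter), and hydroxy in place of fluoro gave a 2.2-fold lower number from compound 2 to compound 3 (0.34 log units; beyond the scatter).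

Compound 4 `COc1ccc(N(C)c2ccnc(Cl)n2)cc1OCC[Se]C#N` differs from compound 3 by a single change: a group of 5 heavy atoms (3 carbon, 1 nitrogen, 1 selenium; no ring) in place of a hydrogen atom, on an oxygen on an aromatic ring. Going by the values given here, none of the measured steps alters that oxygen, and no measured compound carries anything comparable to the entering group, so the data offer only indirect guidance. The two hydroxy steps bear on the question only loosely, as they involve the same place on the ring. The larger of them, a 3.5-fold lower number from compound 1 to compound 3 (0.54 log units; beyond the scatter), is modest, so a step of about that size in either direction is the most these data suggest, and they fix no direction. The estimated step is a 1.4-fold lower number from compound 3 to compound 4 (0.15 log units; within the scatter), so no clear change is expected. For compound 4 the expected value is 300 nM, within an estimated range from 70 nM to 1300 nM.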

Compound 4, half-maximal inhibitory concentration: 1220 nM
Beside the measured number, compound 4's estimate is 4.1-fold (0.61 log units) below it, within the range that was stated.
By their numbers in this assay, from the lowest: compound 3; then compounds 2, 4 and 1 (each within the scatter of the next).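

In this assay, placing the group of 5 heavy atoms on the oxygen of compound 3 gave a 2.9-fold higher number from compound 3 to compound 4 (0.46 log units; beyond the scatter), so that oxygen is a place where a change can raise the number, and the lower number of the free hydroxy compound is not kept with this group attached. Against the other two compounds the result reads a 1.3-fold higher number from compound 2 to compound 4 (0.13 log units; within the scatter) and a 1.2-fold lower number from compound 1 to compound 4 (0.08 log units; within the scatter), so with this group at that place on the ring the number cannot be told apart from those seen with fluoro or with hydrogen there. Nothing in the available data accounts for the rise seen on this oxygen.

Going by these compounds, it remains open whether the rise comes from the loss of the hydroxy hydrogen or from the entering group itself, and a simple methyl on that oxygen would help to separate the two. On these data alone, it is equally open whether a sulfur in place of the selenium, or a longer chain ending in an amine, would give a number near compound 4 or near compound 3.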